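A few compounds are considered here, and "the series" means these few. Any claim that something is new, unique, unknown or untested is made for them only; others in the source may bear on it.

Compound 1 `CC(C)N(Cc1cccc(OCCCCCC(=O)O)c1)C(=O)c1ccc(-c2ccsc2)cc1` carries a thiophen-3-yl group on the shared core. In an ADME assay on HepG2 cells (Homo sapiens) for cytotoxicity, read by CellTiter-Glo and resazurin assay, with a stated time of 72 h (a lower number here means that less compound is needed, a higher number that more compound is needed for the effect), compound 1 gives > 26000 nM, which is a limit of the assay rather than a number. Compound 2 `CC(C)N(Cc1cccc(OCCCCCC(=O)O)c1)C(=O)c1ccc(-c2cc3ccccc3n2S(=O)(=O)c2ccccc2)cc1` shares that core. In this assay compound 2 gives > 26000 nM, again a limit. Both compounds sit at the limit of > 26000 nM in this assay, at which 2 of the 2 values shown sit, so compound 1 has no number from which to be ranked. Compound 3 `COc1ccc(F)c(-c2ccc(C(=O)N(Cc3cccc(OCCCCCC(=O)O)c3)C(C)C)cc2)c1` is not yet measured and differs from compound 1 by 2-fluoro-5-methoxyphenyl in place of thiophen-3-yl on an aromatic carbon. The step that the limit leaves unreadable from compound 1 to compound 3 is expected to stay within the scatter, with another limit likely. Compound 3 is estimated at 40000 nM, ranging from 20000 nM to 100000 nM.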

Compound 3, half-maximal effective concentration: > 26000 nM
Compound 3 gave a limit, no number; the forecaster's own chance of this, stated with the estimate: 85%; the middle value is on the limit's open side.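

Going by these compounds alone, compound 3, like compound 1, gives only a limit in this assay, so no step between compound 1 and compound 3 can be read. The compounds shown leave open whether swapping thiophen-3-yl for 2-fluoro-5-methoxyphenyl changes the half-maximal effective concentration at all, because all values shown stand at one limit: the limit of > 26000 nM in this assay, at which 3 of the 3 values shown sit.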